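The compounds below may be only part of what the source reports. "The series", "measured", "known", "first", "only" and "open" are said of these compounds alone.

Measured compounds:
compound 1 `CCCc1nc(-c2ccccc2)c(CNCCN2CCN(c3ccccc3OC)CC2)o1` with 39.7%
compound 2 `CCCc1nc(-c2ccccc2)c(CNCCCN2CCN(c3cccc(C)c3C)CC2)o1` with 55.2%

The two compounds share a core that differs in the linker and in the aromatic ring carried by the piperazine. For the measured compounds named here, in an assay on HEK293 cells for inhibition of Voltage-dependent T-type calcium channel subunit alpha-1G (Homo sapiens), read by fluorescence, tested at 10 uM (on this read-out higher numbers stand for more inhibition at the one concentration tested (going by the name of the read-out) and lower numbers for less inhibition), compound 1 gives 39.7%, the lower of the two numbers known so far, while compound 2 gives 55.2%, a number that lies beyond the usual scatter above it. No pair of these compounds differs in a single place, so no measured step can be stated.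

Compound 3 `CCCc1nc(-c2ccccc2)c(CNCCN2CCN(c3ccccc3)CC2)o1` has not been measured. Compared with compound 1, the change is hydrogen in place of methoxy on an aromatic carbon. Nothing in the two measured compounds shows what removing the methoxy does in this assay, so the expectation rests on the starting number alone. The account expects a step from compound 1 to compound 3 of a number 6.7 percentage points lower from compound 1 to compound 3 (within the scatter), a small decrease that may well stay within the scatter. For compound 3 the estimate in this assay is 33%, expected to fall between 15% and 55%.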

Compound 3, a percentage reported as inhibition, at one concentration (the size of the read-out at that concentration, not a potency): 54.3%
Beside the measured number, compound 3's estimate is 21.3 percentage points below it, within the range that was stated.
By their numbers in this assay, from the lowest: compound 1; then compounds 3 and 2 (each within the scatter of the next).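

In this assay, for the compounds shown here, hydrogen in place of methoxy on an aromatic carbon, ortho to a large group, gives a number 14.6 percentage points higher from compound 1 to compound 3 (beyond the scatter), the first step that can be tied to a single place. It shows that the methoxy at this position is not required for the inhibition seen at the one concentration tested, and that, with the linker shared by these two compounds, the 2-methoxyphenyl compound has the lower number of the pair. Nothing available here accounts for the size or direction of this step.

The compounds shown leave open whether this step is particular to methoxy or would also appear with another group at the same position, such as fluorine, a hydroxyl or a methyl. They also leave open whether the change from 2-methoxyphenyl to phenyl would have the same effect on a compound with a longer chain between the shared core and the piperazine, and how such a step would look as a potency rather than as inhibition at one concentration.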